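Cyano for ethyl on the pyrimidine of compound 3

A few compounds are considered here, and "the series" means these few. Any claim that something is new, unique, unknown or untested is made for them only; others in the source may bear on it.

Measured so far:
compound 1 `Fc1ccc2nc(-c3cncnc3)n(C3CC3)c2c1`, 40 nM
compound 2 `Fc1ccc2nc(-c3cccnn3)n(C3CC3)c2c1`, 412 nM
compound 3 `CCc1ncncc1-c1nc2cc(F)c(F)cc2n1C1CC1`, 8 nM

In an assay on cells for inhibition of cytochrome P450 11B2, mitochondrial (Homo sapiens), read by HPLC, with a stated time of 90 min (on this read-out higher numbers stand for weaker inhibition and lower numbers for stronger inhibition), compound 3 gives 8 nM, the lowest of the three numbers; compound 1 gives 40 nM and compound 2 gives 412 nM. Within the data shown here, the only step between compounds differing in one place is a 10-fold higher number from compound 1 to compound 2 (1.01 log units; beyond the scatter). Compound 4 `N#Cc1ncncc1-c1nc2cc(F)c(F)cc2n1C1CC1` arises from compound 3 by the change (cyano in place of ethyl on an aromatic carbon). Among the measured compounds shown here, none of the measured steps touches this position or this pair of groups; the step from compound 1 to compound 2 concerns an exchange of the whole six-membered ring, not a substituent on it. There is therefore no measured basis for a step of a given size in this assay, and the expectation is for no change beyond the scatter, with the uncertainty left open in both directions. For compound 4 the estimate is 10 nM, within 3 nM to 40 nM, which means an expected step of a 1.3-fold higher number from compound 3 to compound 4 (0.10 log units; within the scatter).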

Compound 4, half-maximal inhibitory concentration: 13 nM
Beside the measured number, compound 4's estimate is 1.3-fold (0.11 log units) below it; measured number inside the range.
By their numbers in this assay, from the lowest: compounds 3 and 4 (each within the scatter of the next); then compound 1; then compound 2.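

In this assay, cyano in place of ethyl on the aromatic carbon next to the ring nitrogen gives a 1.6-fold higher number from compound 3 to compound 4 (0.21 log units; within the scatter), so the two compounds cannot be told apart on this read-out. Among these compounds, this is the first measured step at this position, and it shows that these two groups, each of the same heavy-atom count, can be exchanged here without a change beyond the scatter, although cyano brings a triple bond and a hydrogen-bond acceptor that ethyl lacks. No available evidence explains why the number holds across this exchange.

The compounds shown leave open whether this holds for other groups at this position, such as an amine, a carboxylic acid or a longer chain like butyl. They also leave open how a plain hydrogen here would compare with ethyl and cyano on the same core.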